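The source may hold more compounds than are shown below. What is called first, only, known or untested is meant among the compounds shown, and "the series" means these compounds.

Measured so far in an ADME assay for permeability, using PAMPA, with a stated time of 30 min, at pH 7.4; on this read-out higher numbers stand for higher permeability and lower numbers for lower permeability:
compound 1, `COc1ccc(-c2ccc3c(NCCCNCc4cccc(OC)c4O)ccnc3c2)cc1`: 237 10^-6 cm/s
compound 2, `COc1ccccc1Oc1ccc2c(NCCCNCc3ccco3)ccnc2c1`: 317 10^-6 cm/s
compound 3, `COc1cccc(CNCCCNc2ccnc3cc(Oc4ccc(F)cc4)ccc23)c1O`: 317 10^-6 cm/s

Within the data shown here, on these numbers compound 3 stands level with compound 2 at the digits printed, the two together the highest of the three; compound 1 is the nearest other point, and the only single-point step measured, a 1.3-fold higher number from compound 1 to compound 3 (0.13 log units; within the scatter), lies within the scatter. All three compounds therefore sit within a narrow band on this assay.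

Compound 4, `COc1ccccc1Oc1ccc2c(NCCCNCc3cccc(OC)c3O)ccnc2c1`, differs from compound 3 by 2-methoxyphenyl in place of 4-fluorophenyl on an oxygen on an aromatic ring. Among the measured compounds shown here, the one measured step that bears on this position, a 1.3-fold higher number from compound 1 to compound 3 (0.13 log units; within the scatter), also exchanged the aryl group on that side of the shared core and produced nothing beyond the scatter. For the measured compounds named here, compound 2 already carries the 2-methoxyphenoxy group that enters in compound 4, and in this assay compound 2 gives 317 10^-6 cm/s, which agrees with compound 3 at the digits printed; no step between compound 2 and compound 4 has been measured, so only those two values speak. No step beyond the scatter is expected from compound 3 to compound 4: the estimated step is a 1.1-fold lower number from compound 3 to compound 4 (0.02 log units; within the scatter). The value of compound 4 in this assay is estimated at 300 10^-6 cm/s, with a range from 180 10^-6 cm/s to 480 10^-6 cm/s.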

Compound 4, apparent permeability: 317 10^-6 cm/s
Estimate against measurement, compound 4: 1.1-fold (0.02 log units) below; the measured number falls inside the stated range.
By their numbers in this assay, from the lowest: compounds 1, 2, 3 and 4 (each within the scatter of the next).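

In this assay the change at this position, on an oxygen on an aromatic ring, now has a direct reading: 2-methoxyphenyl in place of 4-fluorophenyl gives no change at the digits printed from compound 3 to compound 4 (within the scatter) and stays within the scatter. The two other steps read the same way, with 2-hydroxy-3-methoxyphenyl in place of furan-2-yl giving no change at the digits printed from compound 2 to compound 4 (within the scatter) and 2-methoxyphenoxy in place of 4-methoxyphenyl giving a 1.3-fold higher number from compound 1 to compound 4 (0.13 log units; within the scatter) without any step beyond the scatter. The compounds shown come with no evidence that accounts for these readings.

Still open, as far as these compounds go, is whether a carboxylic acid or an amine carried on the aryl group at this oxygen would also stay within the scatter. A longer chain in place of the saturated chain is equally open, since all the steps shown leave that chain unchanged.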